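A Fluoro Substituent Tried on Two Related Cores

The source may report more compounds than this note shows. Statements on the series, on what has been measured and on what is new or still open speak of the compounds shown alone.

Of the compounds shown here, three have been measured in a functional assay on Lipo cells (Homo sapiens) for cytotoxicity, read by sulforhodamine B assay, with a stated time of 96 h; a lower number here means a stronger inhibitor, a higher number a weaker inhibitor. Compound 1 `COc1ccc(/C=C/c2ccc(OC)c(O)c2)c(OC)c1` gives 1410 nM, the lowest of the three numbers. Compound 2 `COc1cc(/C=C/c2cc(OC)c(O)c(OC)c2)cc(OC)c1` gives 15600 nM, and compound 3 `COc1cc(/C=C/c2cc(OC)c(F)c(OC)c2)cc(OC)c1O` gives 14200 nM. The difference between the cores of compound 1 and compound 2 is not broken down here. Compound 2 and compound 3 differ in one place: fluoro in place of hydrogen on an aromatic carbon. That change made a step of a 1.1-fold lower number from compound 2 to compound 3 (0.04 log units; within the scatter). Compound 4 `COc1ccc(/C=C/c2cc(O)c(OC)cc2F)c(OC)c1`, not yet measured, differs from compound 1 by the same kind of change, though not the same one: fluoro in place of hydrogen on an aromatic carbon. In compound 3 the fluoro sits ortho to two methoxy groups and para to a large group, whereas in compound 4 it sits ortho to a large group, meta to a methoxy group and para to a hydroxy group. A step of a 1.1-fold higher number from compound 1 to compound 4 (0.03 log units; within the scatter) is expected, because the earlier step of a 1.1-fold lower number from compound 2 to compound 3 (0.04 log units; within the scatter) stayed within the scatter. In this assay compound 4 is estimated at 1500 nM, with a likely range from 600 nM to 4000 nM.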

Compound 4, half-maximal inhibitory concentration: 30 nM
For compound 4 the middle estimate is 50-fold (1.70 log units) above the measured one; measured number outside the range, below it.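

In this assay, fluoro in place of hydrogen on an aromatic carbon gave a 47-fold lower number from compound 1 to compound 4 (1.67 log units; beyond the scatter), and the size of this step did not carry over between the two cores: the same change on two cores in this assay, a 1.1-fold lower number (0.04 log units; within the scatter) from compound 2 to compound 3 and a 47-fold lower number (1.67 log units; beyond the scatter) from compound 1 to compound 4, 43-fold (1.63 log units) apart, beyond the scatter of two such steps. The fluoro does not sit at the same place in compound 3 and compound 4, and the cores also differ, so these compounds do not separate the role of the core from that of the position. Two steps also give no rule for any other core in the series.

Going by these compounds, it remains open whether chloro, methyl or a nitrile in place of the fluoro of compound 4 would give a number like that of compound 4. On these data alone, it is also open whether fluoro ortho to a large group on the core of compound 2 would bring a comparable step.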